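Shortening an acid-tipped ether chain: what to expect

The compounds below may be only part of what the source reports. "The series", "measured", "known", "first", "only" and "open" are said of these compounds alone.

Compound 3 `O=C(O)CCCCCCCCCOc1ccc2c(=O)c(-c3ccc(O)cc3)coc2c1` stands second of three in a functional assay on mitochondria (Cricetulus griseus) for inhibition of Monoamine oxidase (Homo sapiens), tested at 0.9 uM (on this read-out higher numbers stand for a stronger effect at the one concentration tested and lower numbers for a weaker effect), giving 85.1%. Compound 1 `CCOc1ccc2c(=O)c(-c3ccc(O)cc3)coc2c1` gives 86.9% in this assay, and compound 2 `O=c1c(-c2ccc(O)cc2)coc2cc(OCCCBr)ccc12` gives 67.7%. The step of a number 1.8 percentage points lower from compound 1 to compound 3 (within the scatter) shows that a long acid-ended chain in place of the short ether leaves the read-out essentially unchanged, whereas a number 19.2 percentage points lower from compound 1 to compound 2 (beyond the scatter) and a number 17.4 percentage points higher from compound 2 to compound 3 (beyond the scatter) show that only the bromo-ended chain falls away. Compound 4 `O=C(O)CCCCCCOc1ccc2c(=O)c(-c3ccc(O)cc3)coc2c1` differs from compound 3 by carboxy in place of 3-carboxypropyl on a saturated chain carbon, six bonds along the chain from an oxygen on an aromatic ring. Going by the values given here, no measured step shortens such a chain directly; the nearest evidence, a number 1.8 percentage points lower from compound 1 to compound 3 (within the scatter), suggests that chain length has little bearing here. Compound 4 is therefore expected to give 82% (range 68% to 92%), a step of a number 3.1 percentage points lower from compound 3 to compound 4 (within the scatter) that is expected to stay within the scatter.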

Compound 4, a percentage reported as inhibition, at one concentration (the size of the read-out at that concentration, not a potency): 71.2%
The estimate for compound 4 lay 10.8 percentage points above the measured number; the range from low to high includes it.
By their numbers in this assay, from the lowest: compounds 2 and 4 (each within the scatter of the next); then compounds 3 and 1 (each within the scatter of the next).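

In this assay the length of the acid-ended chain does matter at this position: carboxy in place of 3-carboxypropyl gives a number 13.9 percentage points lower from compound 3 to compound 4 (beyond the scatter) and 4-carboxybutyl in place of hydrogen gives a number 15.7 percentage points lower from compound 1 to compound 4 (beyond the scatter) in the comparison with the short ether. The shorter acid-ended chain also sits close to the bromo-ended chain, with a number 3.5 percentage points higher from compound 2 to compound 4 (within the scatter) and so the tolerance seen for compound 3 does not extend to every acid-ended chain. No evidence at hand accounts for this drop. Open, on these data alone, is whether the read-out falls gradually or abruptly across chain lengths between those of compound 4 and compound 3. Also open, as far as these compounds go, is whether an amine or a methyl ester at the chain end would behave like the carboxylic acid.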